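The compounds below may be only part of what the source reports. "The series", "measured", "known", "first", "only" and "open" are said of these compounds alone.

Working notes on the series. In a functional assay on HCT-116 cells (Homo sapiens) for inhibition, read by MTT assay, with a stated time of 72 h (on this read-out lower numbers stand for stronger inhibition of growth and higher numbers for weaker inhibition of growth), compound 1 (`CN1CCN(C(=O)/C=C/c2ccncc2-c2ccc3ccccc3c2)CC1`) gives > 30000 nM, which is a limit and not a number. Within the data shown here, compound 2 (`CCOC(=O)/C=C/c1ccncc1-c1ccc2ccccc2c1`) gives 910 nM, the only true number so far.

Among the measured compounds shown here, the only measured step is an at least 32-fold lower number from compound 1 to compound 2 (1.51 log units; beyond the scatter), with ethoxy in place of 4-methylpiperazin-1-yl on a carbonyl carbon. This step is large, and it shows that the number responds strongly to what sits on that carbonyl.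

Compound 3 (`O=C(O)/C=C/c1ccncc1-c1ccc2ccccc2c1`) keeps the shared core and changes the same end of the molecule: hydrogen in place of ethyl on an oxygen next to a carbonyl group, or ethoxycarbonyl to carboxy. No change of this kind has been measured in the series, so the direction rests on a single precedent. Read backwards, an at least 32-fold lower number from compound 1 to compound 2 (1.51 log units; beyond the scatter) shows the one measured departure from ethoxy giving weaker growth inhibition, and a move the same way, beyond the scatter but possibly smaller, is expected here.

The estimated change is a 6.6-fold higher number from compound 2 to compound 3 (0.82 log units; beyond the scatter). For compound 3 the estimated value is 6000 nM, with an expected range of 1500 nM to 25000 nM.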

Compound 3, concentration for 50% growth inhibition: > 30000 nM
Compound 3: a limit, no number; the forecaster's own chance of this, stated with the estimate: 30%; middle value at least 5.0-fold (0.69 log units) from the limit.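

The change from ethoxycarbonyl to carboxy alone is enough to take the series out of the readable range in this assay: an at least 32-fold higher number from compound 2 to compound 3 (1.51 log units; beyond the scatter). Losing only the ethyl, with its 2 carbons, therefore has an effect that reaches the limit of the read-out, so the first departure from ethoxy was not a special case of the larger 4-methylpiperazin-1-yl group. Among the three compounds, both departures from ethoxy on that carbonyl end at the same limit, and the step between compound 1 and compound 3 cannot be read, so these two departures remain unranked: the limit of > 30000 nM in this assay, at which 2 of the 3 values shown sit.

From the compounds shown here alone, the full size of both losses stays unknown, as does how much of the ethyl is needed, and a methyl ester or a longer chain such as a butyl ester would test this against compound 2 at 910 nM. A simple primary amide on the same carbonyl would show whether growth inhibition in this series is confined to esters or extends to other carbonyl groups.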